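A few compounds are considered here, and "the series" means these few. Any claim that something is new, unique, unknown or untested is made for them only; others in the source may bear on it.

Measured in a functional assay on MCF7 cells (Homo sapiens) for cytotoxicity, read by MTT assay, with a stated time of 48 h; on this read-out higher numbers stand for weaker inhibition and lower numbers for stronger inhibition:
- compound 1 `C=C1CC[C@@H]2[C@](C)(CO)[C@H](O)CC[C@@]2(C)[C@@H]1CCc1ccoc1`: 79500 nM
- compound 2 `C=C1CC[C@@H]2[C@](C)(COC(=O)COc3ccccc3)[C@H](O)CC[C@@]2(C)[C@@H]1CCc1ccoc1`: 36800 nM
- compound 3 `C=C1CC[C@@H]2[C@](C)(COC(=O)c3ccc([N+](=O)[O-])cc3)[C@H](O)CC[C@@]2(C)[C@@H]1CCc1ccoc1`: 62100 nM

Compound 3, at 62100 nM, cannot be ranked against the other two, since its distance from each lies within the scatter: a 1.3-fold lower number from compound 1 to compound 3 (0.11 log units; within the scatter) and a 1.7-fold higher number from compound 2 to compound 3 (0.23 log units; within the scatter). The next analogue, compound 4 `C=C1CC[C@@H]2[C@](C)(COC(=O)c3ccc(OC)cc3)[C@H](O)CC[C@@]2(C)[C@@H]1CCc1ccoc1`, carries methoxy in place of nitro on an aromatic carbon, para to a large group (methoxy in place of nitro on an aromatic carbon).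

Among the measured compounds shown here, no measured step makes this exact swap, so the nearest evidence is what happened when the ester group changed. For the measured compounds named here, only one such step clears the scatter, and modestly: a 2.2-fold lower number from compound 1 to compound 2 (0.33 log units; beyond the scatter). The replacement of phenoxymethyl by 4-nitrophenyl on the carbonyl carbon, given above for compound 3, stayed within it. On that basis, no step beyond the scatter is expected in this assay, in either direction. The expected step is a 1.1-fold lower number from compound 3 to compound 4 (0.05 log units; within the scatter). For compound 4 the estimated value is 55000 nM, with an expected range from 28000 nM to 100000 nM.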

Compound 4, half-maximal inhibitory concentration: 25200 nM
Estimate against measurement, compound 4: 2.2-fold (0.34 log units) above; the whole stated range lies above it.
By their numbers in this assay, from the lowest: compounds 4, 2, 3 and 1 (each within the scatter of the next, the first and the last beyond it).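

In this assay the substituent on this aromatic ring clearly counts, since methoxy in place of nitro, para to a large group, gives (a 2.5-fold lower number from compound 3 to compound 4 (0.39 log units; beyond the scatter)) with the rest of the molecule unchanged. The ester carrying methoxy also stands clear of the free alcohol (a 3.2-fold lower number from compound 1 to compound 4 (0.50 log units; beyond the scatter)), which the nitro ester did not, while it cannot be separated from the phenoxymethyl ester (a 1.5-fold lower number from compound 2 to compound 4 (0.16 log units; within the scatter)). No measurement shown here explains why the swap has this effect.

Going by these compounds, only nitro and methoxy are seen at this ring carbon, so it remains open whether an amine or a carboxylic acid there would fall nearer compound 3 or compound 4. On these data alone, the other hydroxyl on the shared core stays free in all four compounds, so an ester at that oxygen remains untested here.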